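The source may hold more compounds than are shown below. What is called first, only, known or untested is meant among the compounds shown, and "the series" means these compounds.

Measured so far:
- compound 1 `CCOC(=O)c1cc(N2C(=O)C3=C(CCCC3)C2=O)c(F)cc1Cl`: 87.1 nM
- compound 2 `CCOC(=O)c1cc(N2C(=O)C3=C(CCCC3)C2=O)ccc1Cl`: 2140 nM

In a functional assay on the whole organism with Scenedesmus acutus as the target, with a stated time of 20 h (on this read-out higher numbers stand for weaker inhibition and lower numbers for stronger inhibition), compound 1 gives 87.1 nM, the lower of the two numbers, which makes it the stronger inhibitor of this pair. Among the measured compounds shown here, the only measured step, a 25-fold higher number from compound 1 to compound 2 (1.39 log units; beyond the scatter), is large and puts hydrogen in place of fluoro on an aromatic carbon.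

Compound 3 `CC(C)OC(=O)c1cc(N2C(=O)C3=C(CCCC3)C2=O)c(F)cc1Cl` keeps that fluoro and changes something else: methyl in place of hydrogen on a saturated chain carbon bound to an oxygen next to a carbonyl group and a saturated chain carbon. Put simply, ethoxycarbonyl becomes isopropoxycarbonyl. For the measured compounds named here, the step of a 25-fold higher number from compound 1 to compound 2 (1.39 log units; beyond the scatter) concerns an aromatic carbon, so it does not show what this change will do, and no measured pair varies the ethoxycarbonyl group. On this thin evidence, no step beyond the scatter is expected in this assay, and neither direction is favoured. The estimated change is a 1.1-fold higher number from compound 1 to compound 3 (0.06 log units; within the scatter). The expected value for compound 3 is 100 nM, with a range of 30 nM to 330 nM.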

Compound 3, half-maximal inhibitory concentration: 89.1 nM
Beside the measured number, compound 3's estimate is 1.1-fold (0.05 log units) above it, within the range that was stated.
By their numbers in this assay, from the lowest: compounds 1 and 3 (each within the scatter of the next); then compound 2.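

In this assay, among the compounds shown here, this is the first measured change to the ethoxycarbonyl group, and a 1.0-fold higher number from compound 1 to compound 3 (0.01 log units; within the scatter) lies within the scatter, so the isopropoxycarbonyl and ethoxycarbonyl compounds cannot be told apart here. The extra methyl on the saturated chain carbon bound to the oxygen therefore gives a very different picture from the earlier aromatic change, where a 25-fold higher number from compound 1 to compound 2 (1.39 log units; beyond the scatter) lies beyond the scatter. The data shown offer no measurement that explains this tolerance of the added methyl.

Still open, from the compounds shown here alone, is whether a longer chain such as butyl, a bulkier tert-butyl group, or a free carboxylic acid in place of the ester would also stay within the scatter of compound 1. Going by these compounds, it is also open whether the same methyl would behave alike on compound 2, which carries hydrogen in place of fluoro.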